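This account rests on a few compounds, and the source may have more. Where it says the series, first, only, none or still open, it means among the compounds named here.

Compound 1 `CCOC(=O)c1sc2ccccc2c1Nc1cc(OC)c(OC)c(OC)c1` carries an ethyl ester on the shared core. In a functional assay on MCF7 cells (Homo sapiens) for cytotoxicity, read by MTT assay, with a stated time of 72 h (a higher number here means a weaker inhibitor, a lower number a stronger inhibitor), compound 1 gives 6390 nM. Compound 2 `CCOC(=O)c1sc2cccc(C)c2c1Nc1cc(OC)c(OC)c(OC)c1` adds a methyl group to one ring of that core; the difference is methyl in place of hydrogen on an aromatic carbon. In this assay compound 2 gives 4150 nM, which is a 1.5-fold lower number from compound 1 to compound 2 (0.19 log units; within the scatter). Compound 3 `COC(=O)c1sc2ccccc2c1Nc1cc(OC)c(OC)c(OC)c1` keeps the unsubstituted rings of compound 1 but shortens the ester; the difference between the two cores is hydrogen in place of methyl on a saturated chain carbon bound to an oxygen next to a carbonyl group. In this assay compound 3 gives 795 nM, a step of an 8.0-fold lower number from compound 1 to compound 3 (0.91 log units; beyond the scatter).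

Compound 4 `COC(=O)c1sc2ccc(C)cc2c1Nc1cc(OC)c(OC)c(OC)c1` has not yet been measured. It differs from compound 3 by methyl in place of hydrogen on an aromatic carbon. Among the measured compounds shown here, this is the same kind of change as the one from compound 1 to compound 2, but not the same: there the methyl sat ortho to a fused ring and meta to a fused ring, whereas here it sits meta to a fused ring and para to a fused ring. Because the earlier methyl gave only a 1.5-fold lower number from compound 1 to compound 2 (0.19 log units; within the scatter), a similarly small step is expected, so compound 4 is estimated at 600 nM, a step of a 1.3-fold lower number from compound 3 to compound 4 (0.12 log units; within the scatter), with a range of 300 nM to 1300 nM.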

Compound 4, half-maximal inhibitory concentration: 540 nM
For compound 4 the middle estimate is 1.1-fold (0.05 log units) above the measured one; low and high end bracket the measured number.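

In this assay, the methyl group on an aromatic carbon gives a 1.5-fold lower number from compound 3 to compound 4 (0.17 log units; within the scatter), so the two numbers cannot be told apart. Set beside the earlier methyl step, the result on the second core matches the one on the first: the same change on two cores in this assay, a 1.5-fold lower number (0.19 log units; within the scatter) from compound 1 to compound 2 and a 1.5-fold lower number (0.17 log units; within the scatter) from compound 3 to compound 4, 1.0-fold (0.02 log units) apart, within the scatter of two such steps. Among the compounds shown here, this shows that, on both the ethyl ester core and the methyl ester core, adding a methyl group to this ring left the number within the scatter, but it does not establish a rule for the series, since there are only two pairs, the methyl sits at a different place on the ring in each, and a small real effect could be hidden in the scatter.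

The compounds shown leave open whether a larger or different group on that ring, such as a chlorine or an amine, would give a step beyond the scatter. They also leave open how a carboxylic acid or an amide in place of the ester would compare with compound 3.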